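The source may hold more compounds than are shown below. What is called first, only, known or untested is meant among the compounds shown, and "the series" means these compounds.

Measured so far in an ADME assay on WiDr cells (Homo sapiens) for cytotoxicity, read by MTT assay; a lower number here means that less compound is needed, a higher number that more compound is needed for the effect

Compound 1 `C=C1CCCC(C)(C)[C@@H]1C[C@H](O)/C(C)=C/CC[C@@H]1[C@@]2(C)CCCC(C)(C)[C@@H]2CC[C@@]1(C)O` gives 7.8 ug/mL as a number

Compound 2 `C=C1CCCC(C)(C)[C@@H]1C[C@@H](O)/C(C)=C/CC[C@@H]1[C@@]2(C)CCCC(C)(C)[C@@H]2CC[C@@]1(C)O` gives > 10 ug/mL as a limit

Compound 3 `C=C1CCCC(C)(C)[C@@H]1CC/C(=C\CC[C@@H]1[C@@]2(C)CCCC(C)(C)[C@@H]2CC[C@@]1(C)O)CO` gives > 10 ug/mL as a limit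

In this assay compound 2 gives > 10 ug/mL and this is a limit, not a number. Its true position is therefore open, and any step starting from it is poorly anchored.

Compound 4 `C=C1CCCC(C)(C)[C@@H]1C[C@@H](OC(=O)c1ccccc1)/C(C)=C/CC[C@@H]1[C@@]2(C)CCCC(C)(C)[C@@H]2CC[C@@]1(C)O` is next to be read. It differs from compound 2 by benzoyl in place of hydrogen on an oxygen on a saturated carbon and this turns hydroxy into benzoyloxy.

Within the data shown here, the only measured step is an at least 1.2-fold higher number from compound 1 to compound 2 (0.10 log units; that floor lies within the scatter) and it bears on this change only weakly, since it rests on the fact that compounds 1 and 2 differ only in the configuration as drawn and is capped by the limit of > 10 ug/mL in this assay, at which 2 of the 3 values shown sit, in what it can show. Among the measured compounds shown here, no measured compound carries anything but hydrogen on that oxygen, so the data give no size for this change.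

No shift beyond the scatter is therefore expected, and the estimated change is a number no higher from compound 2 to compound 4 (the limit leaves the size open) with either direction still possible. A further limit is a likely outcome. Compound 4 is expected to read about 10 ug/mL with an estimated range from 5 ug/mL to 20 ug/mL in this assay when measured.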

Compound 4, concentration for half-maximal effect: > 10 ug/mL
Compound 4: no number, only a limit (the forecaster's own chance of this, stated with the estimate: 60%); the middle value lies on the limit itself.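

In this assay compound 4 gives > 10 ug/mL, which is a limit and not a number. Compound 2 gives > 10 ug/mL, also a limit, and the step between compound 2 and compound 4 cannot be read. The compounds shown leave open whether benzoyl in place of hydrogen on that oxygen shifts the reading at all.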